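Triazole substituent swap in a cytotoxicity series

A few compounds are considered here, and "the series" means these few. Any claim that something is new, unique, unknown or untested is made for them only; others in the source may bear on it.

Measured compounds:
compound 1, `CCCCc1cn(C(c2ccccc2)c2cc3cc(Br)ccc3nc2OC)nn1`: 11.1%
compound 2, `COc1nc2ccc(Br)cc2cc1C(c1ccccc1)n1cc(-c2ccc(OC(F)(F)F)cc2)nn1`: 14.8%

In an ADME assay on SK-OV-3 cells (Homo sapiens) for cytotoxicity, read by sulforhodamine B assay, with a stated time of 48 h, tested at 10 uM (on this read-out higher numbers stand for more inhibition at the one concentration tested (going by the name of the read-out) and lower numbers for less inhibition), compound 1 gives 11.1% and compound 2 gives 14.8%. Among the measured compounds shown here, of the two numbers, that of compound 2 is the larger, yet the only measured step is a number 3.7 percentage points higher from compound 1 to compound 2 (within the scatter), so the two compounds cannot be separated.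

Compound 3, `COc1nc2ccc(Br)cc2cc1C(c1ccccc1)n1cc(CCCCCO)nn1`, differs from compound 2 as follows: 5-hydroxypentyl in place of 4-(trifluoromethoxy)phenyl on an aromatic carbon.

For the measured compounds named here, the one measured step, a number 3.7 percentage points higher from compound 1 to compound 2 (within the scatter), exchanged a chain for an aromatic group on the same ring carbon without moving the read-out beyond the scatter. Going by the values given here, no measured step covers a hydroxyl-bearing chain, so the bearing of that change is unknown. Among the compounds with values here, both measured numbers sit low, and the single step was flat; compound 3 is therefore expected to stay in the same region, with a step of a number 2.8 percentage points lower from compound 2 to compound 3 (within the scatter) that is not expected to exceed the scatter.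

Compound 3 is estimated at 12%, with a range from 0% to 28%.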

Compound 3, a percentage reported as inhibition, at one concentration (the size of the read-out at that concentration, not a potency): 8.69%
Compound 3: the middle estimate sits 3.3 percentage points above what was measured; measured number inside the range.
By their numbers in this assay, from the lowest: compounds 3, 1 and 2 (each within the scatter of the next).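

In this assay, 5-hydroxypentyl in place of 4-(trifluoromethoxy)phenyl on the aromatic carbon of the five-membered ring gives a number 6.1 percentage points lower from compound 2 to compound 3 (within the scatter), and hydroxymethyl in place of hydrogen on the butyl chain gives a number 2.4 percentage points lower from compound 1 to compound 3 (within the scatter). A hydroxyl-bearing chain at this position therefore cannot be separated from either the plain butyl chain or the aromatic group, so neither the loss of the ring nor the added hydroxyl shows a readable effect here. No measurement available here explains this flat result.

From the compounds shown here alone, whether an amine or a carboxylic acid in place of the hydroxyl of 5-hydroxypentyl would move the read-out beyond the scatter remains open. The same holds for a longer chain on this aromatic carbon.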